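The source may report more compounds than this note shows. Statements on the series, on what has been measured and on what is new or still open speak of the compounds shown alone.

Measured so far in a functional assay on HUVEC cells (Homo sapiens), read by BrdU incorporation, with a stated time of 72 h; on this read-out higher numbers stand for weaker inhibition and lower numbers for stronger inhibition:
Compound 1 `Cc1cccc2cc(/C=C/C(=O)c3ccc(Br)s3)c(Cl)nc12` gives 243 nM
Compound 2 `Cc1ccc2nc(Cl)c(/C=C/C(=O)c3sccc3Cl)cc2c1` gives 37.5 nM

Compound 2 has the lower of these two numbers, which means the stronger inhibition, and the gap to compound 1 is larger than the usual scatter. Compound 3 `Cc1ccc2nc(Cl)c(/C=C/C(=O)c3sccc3Br)cc2c1` has not yet been measured. It is compound 2 with a single swap, bromo in place of chloro on an aromatic carbon, so that 3-chlorothiophen-2-yl becomes 3-bromothiophen-2-yl (bromo in place of chloro on an aromatic carbon). Within the data shown here, no measured pair here shows this swap, so the data give no direct guide to its size. The natural starting point is therefore compound 2 (37.5 nM) itself. The estimated step of a 1.1-fold higher number from compound 2 to compound 3 (0.03 log units; within the scatter) is expected to stay within the scatter, with neither direction favoured. The estimated value of compound 3 is 40 nM with 15 nM to 110 nM as its expected range.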

Compound 3, half-maximal inhibitory concentration: 61.9 nM
The estimate for compound 3 lay 1.5-fold (0.19 log units) below the measured number; low and high end bracket the measured number.
By their numbers in this assay, from the lowest: compounds 2 and 3 (each within the scatter of the next); then compound 1.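

In this assay, replacing chloro with bromo, which turns 3-chlorothiophen-2-yl into 3-bromothiophen-2-yl, gives a 1.7-fold higher number from compound 2 to compound 3 (0.22 log units; within the scatter), so the two compounds cannot be told apart on this read-out. Among these compounds, this is the first single-place comparison, and it shows that on this aromatic carbon, next to the ring atom that bears a large group, either of these two groups fits with a step that stays within the scatter. Nothing in the data shown explains the size of this step.

Chloro and bromo are only two options, so it remains open whether a hydrogen, a fluoro, a methyl or an amine at this same place would keep the number. Also open is whether moving the chloro elsewhere on this ring matters, as no pair shown changes only its place.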